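A few compounds are considered here, and "the series" means these few. Any claim that something is new, unique, unknown or untested is made for them only; others in the source may bear on it.

Within the data shown here, in a functional assay on cells (Homo sapiens) for antiproliferative activity, read by MTT assay, with a stated time of 48 h (on this read-out higher numbers stand for weaker inhibition and lower numbers for stronger inhibition), compound 2 (`CN(C)CCn1c(N)c(-c2nc3ccccc3[nH]2)c2nc(C#N)c(C#N)nc21`) gives 43500 nM as the only actual number so far. Compound 1 (`CCn1c(N)c(-c2nc3ccccc3[nH]2)c2nc(C#N)c(C#N)nc21`) stands at > 50000 nM as a limit of the assay. Compound 3 (`CN(C)CCn1c(N)c(-c2nc3ccccc3s2)c2nc(C#N)c(C#N)nc21`) stands at > 50000 nM as a limit too. Compound 4 (`CN(C)CCn1c(N)c(-c2nc3ccccc3n2C)c2nc(C#N)c(C#N)nc21`) carries methyl in place of hydrogen on an aromatic nitrogen of compound 2: methyl in place of hydrogen on an aromatic nitrogen. The step that changes the same large group is an at least 1.1-fold higher number from compound 2 to compound 3 (0.06 log units; that floor lies within the scatter) and the chain step is an at least 1.1-fold lower number from compound 1 to compound 2 (0.06 log units; that floor lies within the scatter), both only floors. Neither measures this methyl, so no step beyond the scatter is expected in this assay in either direction. The expected step is a 1.1-fold higher number from compound 2 to compound 4 (0.06 log units; within the scatter) as an estimate. Given (the limit of > 50000 nM in this assay, at which 2 of the 3 values shown sit), compound 4 may also return only a limit. For compound 4 the estimated value is 50000 nM, with an expected range of 25000 nM to 100000 nM.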

Compound 4, half-maximal inhibitory concentration: > 50000 nM
Compound 4 was reported as a limit; the forecaster's own chance of this, stated with the estimate: 60%; the middle value sits exactly at the limit.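

In this assay, compound 4 gives > 50000 nM, which is a limit and not a number. Methyl on the aromatic nitrogen gives an at least 1.1-fold higher number from compound 2 to compound 4 (0.06 log units; that floor lies within the scatter), so this position tolerates no reading beyond a floor, and the true size of the step stays unknown. Compound 3 and compound 4, the two changes from compound 2 that remove this nitrogen's hydrogen, both end at the same limit: the limit of > 50000 nM in this assay, at which 3 of the 4 values shown sit.

From the compounds shown here alone, whether the hydrogen itself matters remains open. So does whether ethyl or a hydroxyethyl chain on this nitrogen would return an actual number.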